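Benzyloxy on the aryl ring of a dopamine receptor agonist

The compounds below may be only part of what the source reports. "The series", "measured", "known", "first", "only" and "open" are said of these compounds alone.

Compound 1 `Cc1ccccc1/C(CCN1CCN(c2ccccn2)CC1)=N/O` gives 4.2 nM in a functional assay on HEK293 cells with D(4) dopamine receptor (Homo sapiens) as the target, read by FLIPR; a higher number here means that more compound is needed for the effect, a lower number that less compound is needed. Compound 2 `Cc1cccc(/C(CCN2CCN(c3ccccn3)CC2)=N/O)c1` gives 2.3 nM. Compound 3 `O/N=C(\CCN1CCN(c2ccccn2)CC1)c1ccc(F)cc1` gives 31 nM.

Compound 2 shows the lowest number of the three; the gap to compound 1, a 1.8-fold lower number from compound 1 to compound 2 (0.26 log units; within the scatter), is within the scatter, while a 13-fold higher number from compound 2 to compound 3 (1.13 log units; beyond the scatter) is large. Compound 4 `Cc1ccc(OCc2ccccc2)c(/C(CCN2CCN(c3ccccn3)CC2)=N/O)c1` differs from compound 2 by benzyloxy in place of hydrogen on an aromatic carbon, placed ortho to a large group and para to a methyl group. For the measured compounds named here, no measured step adds a group of this kind; the measured steps only move or swap a small substituent, with a 7.4-fold higher number from compound 1 to compound 3 (0.87 log units; beyond the scatter) showing that such swaps can shift the number markedly. The expected step is therefore uncertain, a 3.5-fold higher number from compound 2 to compound 4 (0.54 log units; beyond the scatter). Compound 4 is estimated at 8 nM, ranging from 1.5 nM to 60 nM.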

Compound 4, half-maximal effective concentration: > 10000 nM
Compound 4: no number, only a limit; the forecaster's own chance of this, stated with the estimate: 5%; middle value at least 1200-fold (3.09 log units) away from the limit.
By their numbers in this assay, from the lowest: compounds 2 and 1 (each within the scatter of the next); then compound 3. At a limit, above all of these: compound 4.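

Adding benzyloxy in place of hydrogen on this aromatic carbon, ortho to a large group and para to a methyl group, gives an at least 4300-fold higher number from compound 2 to compound 4 (3.63 log units; beyond the scatter) in this assay. For the compounds shown here, this far exceeds the largest step among the earlier compounds, a 13-fold higher number from compound 2 to compound 3 (1.13 log units; beyond the scatter), so this single addition at this position costs much more than swapping a small substituent. Compound 4 gives a limit, not a number: the limit of > 10000 nM in this assay, at which 1 of the 4 values shown sits.

On these data alone, whether methoxy or hydroxy on the same carbon would give a measurable number stays open. So does whether benzyloxy on another carbon of the aromatic ring would have the same effect.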